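Sulfonyl aryl variation in a serotonin-6 displacement series

The source may report more compounds than this note shows. Statements on the series, on what has been measured and on what is new or still open speak of the compounds shown alone.

Three analogues share one core and differ only in the aryl group on the sulfonyl sulfur. In an assay on HEK293 cells for displacement of a labelled ligand from 5-hydroxytryptamine receptor 6 (Homo sapiens), with a stated time of 60 min, tested at 0.01 uM, in the presence of a further agent that is not named here (a higher number here means a stronger effect of the compound at the concentration tested, a lower number a weaker effect), compound 1 `COc1ccc(S(=O)(=O)NCCN2CCC(CCC(=O)c3cc(Cl)c(N)cc3OC)CC2)cc1` gives 36%, compound 2 `COc1cc(N)c(Cl)cc1C(=O)CCC1CCN(CCNS(=O)(=O)c2ccc(C)cc2)CC1` gives "not active" (no number reported), and compound 3 `COc1cc(N)c(Cl)cc1C(=O)CCC1CCN(CCNS(=O)(=O)c2ccc(N)c(Br)c2)CC1` gives 39%. Among the measured compounds shown here, compound 3 thus holds the higher of the two reported numbers, with compound 1 nearest, and the one measured step, a number 3 percentage points higher from compound 1 to compound 3 (within the scatter), is small.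

Compound 4 `COc1cc(N)c(Cl)cc1C(=O)CCC1CCN(CCNS(=O)(=O)c2ccc(NC(C)=O)cc2)CC1` is the next analogue: 4-acetamidophenyl in place of 4-amino-3-bromophenyl on a sulfonyl sulfur. For the measured compounds named here, the only step that bears on it is the one from compound 1 to compound 3, which stayed within the scatter, so no step beyond the scatter is expected here either, a number 7 percentage points lower from compound 3 to compound 4 (within the scatter). Compound 4 is therefore estimated at 32% in this assay, within 8% to 55%.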

Compound 4, a percentage reported as inhibition, at one concentration (the size of the read-out at that concentration, not a potency): 7%
Beside the measured number, compound 4's estimate is 25 percentage points above it; measured number outside the range, below it.
By their numbers in this assay, from the lowest: compound 4; then compounds 1 and 3 (each within the scatter of the next).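

In this assay the aryl group on the sulfonyl sulfur is not indifferent: 4-acetamidophenyl in place of 4-amino-3-bromophenyl costs clearly (a number 32 percentage points lower from compound 3 to compound 4 (beyond the scatter)), and acetamido in place of methoxy on an aromatic carbon also costs (a number 29 percentage points lower from compound 1 to compound 4 (beyond the scatter)). The earlier step at this position gave no such separation. No measurement at hand accounts for the loss.

Open, from the compounds shown here alone, is whether the acetyl part carries the loss. A plain amine or a longer acyl chain in place of acetamido on that aromatic carbon would bear on this.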